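This account rests on a few compounds, and the source may have more. Where it says the series, first, only, none or still open, it means among the compounds named here.

Measured in an ADME assay on cells (Hepatocyte, Mus musculus) for metabolic stability; on this read-out lower numbers stand for a shorter-lived compound and higher numbers for a longer-lived compound:
- compound 1 `Cc1ccc(C(=O)OC2CCC(CN3CCN(c4cc(=O)c5cc(C(F)(F)F)cc([N+](=O)[O-])c5s4)CC3)CC2)cc1`: 0.202 h
- compound 2 `COc1ccc(C(=O)OC2CCC(CN3CCN(c4cc(=O)c5cc(C(F)(F)F)cc([N+](=O)[O-])c5s4)CC3)CC2)cc1`: 0.295 h

Going by the values given here, only two numbers are available for this series. Compound 1 gives 0.202 h, and compound 2 gives 0.295 h, so the two lie within the scatter of each other and cannot be ranked.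

The next compound to be tested is compound 3 `O=C(OC1CCC(CN2CCN(c3cc(=O)c4cc(C(F)(F)F)cc([N+](=O)[O-])c4s3)CC2)CC1)c1cccs1`. It keeps the core of compound 1 and carries thiophen-2-yl in place of 4-methylphenyl on a carbonyl carbon.

Among the compounds with values here, only one measured step bears on this change, and only loosely. It is a 1.5-fold higher number from compound 1 to compound 2 (0.16 log units; within the scatter), and it stays within the scatter. That step puts methoxy in place of methyl on an aromatic carbon and keeps the six-membered ring, whereas compound 3 replaces the whole group. Within the data shown here, no measured compound carries thiophen-2-yl, so the data offer no direct guide and no direction. No step beyond the scatter is therefore expected in this assay.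

The expected step is a 1.2-fold higher number from compound 1 to compound 3 (0.09 log units; within the scatter). The estimate for compound 3 is 0.25 h, with an expected range from 0.12 h to 0.5 h.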

Compound 3, half-life: 0.0867 h
Beside the measured number, compound 3's estimate is 2.9-fold (0.46 log units) above it, outside the stated range (below it).
By their numbers in this assay, from the lowest: compound 3; then compounds 1 and 2 (each within the scatter of the next).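

In this assay, thiophen-2-yl in place of 4-methylphenyl on a carbonyl carbon gives a 2.3-fold lower number from compound 1 to compound 3 (0.37 log units; beyond the scatter), and thiophen-2-yl in place of 4-methoxyphenyl gives a 3.4-fold lower number from compound 2 to compound 3 (0.53 log units; beyond the scatter), both beyond the scatter. The earlier exchange of methyl for methoxy on an aromatic carbon had left compound 1 and compound 2 within the scatter of each other, so only replacing the whole group on the carbonyl carbon shows that the half-life responds to a change at this place, with compound 3 the shortest-lived of the three. Nothing available accounts for this shift.

The compounds shown cannot separate the part played by the five-membered ring, by its sulfur atom and by the loss of the methyl or methoxy group, since all of these change together; an unsubstituted phenyl, a furan-2-yl or a 5-methylthiophen-2-yl on the same carbonyl carbon would pull them apart. From the compounds shown here alone, it also remains open whether any group at this place can lift the half-life clearly above the values of compound 1 and compound 2, for instance a pyridyl ring or a longer chain.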